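This account rests on a few compounds, and the source may have more. Where it says the series, first, only, none or still open, it means among the compounds named here.

Compound 1 `C=CCc1ccccc1NCC1=NCCN1` carries an allyl group on its aromatic ring, which is joined through a nitrogen-bearing link to the shared core. In an assay on cells (kidney, strain Sprague-Dawley) for displacement of a labelled ligand from Nischarin (Rattus norvegicus), read by scintillation counting, with a stated time of 30 min (on this read-out higher numbers stand for weaker inhibition and lower numbers for stronger inhibition), compound 1 gives 3.98 nM. Two further compounds keep that core but attach it through a double-bonded link: compound 2 `C(=C/c1ccccc1-c1ccccc1)\C1=NCCN1`, which carries a phenyl and gives 97.7 nM in this assay, and compound 3 `C=CCc1ccccc1/C=C/C1=NCCN1`, which carries an allyl and gives 69.2 nM. Of the three numbers compound 1 has the lowest, and its gaps to compound 2 and to compound 3 are both beyond the scatter, so it is the strongest binder here. Compound 4 `CCCc1ccccc1NCC1=NCCN1` differs from compound 1 by ethyl in place of vinyl on a saturated chain carbon bound to an aromatic carbon, that is, allyl to propyl. Within the data shown here, the only measured step, a 1.4-fold lower number from compound 2 to compound 3 (0.15 log units; within the scatter), swaps phenyl for allyl on a differently linked core and does not touch a double bond within a chain. Among the measured compounds shown here, no measured step therefore bears directly on this change, and compound 4 is expected to stay close to compound 1, with an estimated step of a 1.3-fold higher number from compound 1 to compound 4 (0.10 log units; within the scatter). The estimate for compound 4 is 5 nM, expected to lie between 1.5 nM and 16 nM.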

Compound 4, inhibition constant: 8.32 nM
Compound 4: middle estimate off by 1.7-fold (0.22 log units), on the low side; the range from low to high includes it.
By their numbers in this assay, from the lowest: compound 1; then compound 4; then compounds 3 and 2 (each within the scatter of the next).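

Turning allyl into propyl on a saturated chain carbon bound to an aromatic carbon gives, in this assay, a 2.1-fold higher number from compound 1 to compound 4 (0.32 log units; beyond the scatter). Among these compounds, this is the first measured change at this place, and it shows that removing the double bond from the chain, with no change in the number of heavy atoms, shifts the result towards weaker inhibition, though only modestly. No available evidence accounts for this shift.

The compounds shown leave open how a shorter chain such as methyl, a longer chain such as butyl, or an amine or a carboxylic acid would behave at this place. They also leave open whether the same change from allyl to propyl would have a similar effect in compound 3, whose link to the shared core is different.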